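Trifluoromethyl placement on the aryl ring of the dienone series

This account rests on a few compounds, and the source may have more. Where it says the series, first, only, none or still open, it means among the compounds named here.

In a functional assay on CWR22R cells (Homo sapiens) for cytotoxicity, read by MTT assay, with a stated time of 72 h (a higher number here means a weaker inhibitor, a lower number a stronger inhibitor), compound 2 `CC1=C(/C=C/C(=O)/C=C/c2ccccc2)C(C)(C)CCC1O` gives 8000 nM, the second highest of the three numbers available. Compound 1 `CC1=CCCC(C)(C)C1/C=C/C(=O)/C=C/c1ccccc1F`, which carries a fluorine on the aryl ring and a different core, gives 9400 nM in this assay, a value within the scatter of that of compound 2, so no order between them is claimed. Relative to compound 2, its ortho-trifluoromethyl analogue compound 3 `CC1=C(/C=C/C(=O)/C=C/c2ccccc2C(F)(F)F)C(C)(C)CCC1O` gives 2300 nM in this assay, and the step is a 3.5-fold lower number from compound 2 to compound 3 (0.54 log units; beyond the scatter).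

Compound 4 `CC1=C(/C=C/C(=O)/C=C/c2cccc(C(F)(F)F)c2)C(C)(C)CCC1O` differs from compound 2 in one place: trifluoromethyl in place of hydrogen on an aromatic carbon. For the measured compounds named here, the only measured step that bears on this change is the one from compound 2 to compound 3, where the same group enters the same ring at a different position; that step was modest but beyond the scatter and pointed to a lower number. Going by the values given here, no measured pair shows a trifluoromethyl meta to a large group, so how much of that gain carries over to the new position is not known from these data. A step in the same direction, of similar or somewhat smaller size, is expected in this assay. For compound 4 the expected step is a 2.3-fold lower number from compound 2 to compound 4 (0.36 log units; beyond the scatter). Compound 4 is therefore estimated at 3500 nM, with a range from 1500 nM to 8000 nM.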

Compound 4, half-maximal inhibitory concentration: 1700 nM
The estimate for compound 4 lay 2.1-fold (0.31 log units) above the measured number, and the stated range covers the measured number.
By their numbers in this assay, from the lowest: compounds 4 and 3 (each within the scatter of the next); then compounds 2 and 1 (each within the scatter of the next).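

In this assay, for the compounds shown here, trifluoromethyl in place of hydrogen on an aromatic carbon, meta to a large group, gives a 4.7-fold lower number from compound 2 to compound 4 (0.67 log units; beyond the scatter), so the lower number for this change is no longer tied to the single placement in compound 3. Compound 3 at 2300 nM and compound 4 at 1700 nM lie within the scatter of each other, so this read-out does not separate the two placements of the group on the ring, and no order between them is claimed. Nothing at hand gives a measured explanation for the lower number with this change, or for the two placements reading alike.

Whether the lower number depends on trifluoromethyl itself stays open, as the position meta to a large group is shown here with no other substituent, and a methoxy group, a nitrile, an amine or a carboxylic acid in that place could each read differently. Also open, from the compounds shown here alone, is whether the same change would lower the number on the core of compound 1, which appears here only with a fluorine on the aryl ring.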